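A few compounds are considered here, and "the series" means these few. Any claim that something is new, unique, unknown or untested is made for them only; others in the source may bear on it.

Measured so far:
compound 1 `COc1ccc(Nc2ncc(C(F)(F)F)c(N3Cc4cccc(N(C)S(C)(=O)=O)c4C3)n2)cc1C(F)(F)F` — > 30000 nM
compound 2 `CN(c1cccc2c1CN(c1nc(Nc3ccc(C(F)(F)F)cc3)ncc1C(F)(F)F)C2)S(C)(=O)=O` — > 30000 nM

In a functional assay on OVCAR-3 cells (Homo sapiens) for antiproliferative activity, read by spectrophotometry, with a stated time of 2 days (on this read-out lower numbers stand for stronger inhibition of growth and higher numbers for weaker inhibition of growth), compound 1 gives > 30000 nM, which is a limit of the assay and not a number. Compound 2 likewise gives > 30000 nM in this assay, again a limit rather than a measured value. Compound 1 therefore stands at the limit of > 30000 nM in this assay, at which 2 of the 2 values shown sit, and nothing shown places it more precisely than that. Among the compounds with values here, the only measured step, a step that the two limits leave unreadable from compound 1 to compound 2, exchanges the aryl group on the same nitrogen and leaves the read-out at the same limit, so its size cannot be read. The unmeasured compound 3 `CN(c1cccc2c1CN(c1nc(Nc3cc(Cl)cc(C(F)(F)F)c3)ncc1C(F)(F)F)C2)S(C)(=O)=O` differs from compound 1 in the same part of the molecule: 3-chloro-5-(trifluoromethyl)phenyl in place of 4-methoxy-3-(trifluoromethyl)phenyl on a nitrogen on an aromatic ring. The measured step is the one that bears on this change, and because both of its ends sit at the limit of > 30000 nM in this assay, at which 2 of the 2 values shown sit, it offers no direction and no size. For compound 3 the expected step of a number no higher from compound 1 to compound 3 (the limit leaves the size open) is accordingly none beyond the scatter, with the result most likely remaining a limit. Compound 3 is expected to give about 30000 nM, within a range from 8000 nM to 100000 nM.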

Compound 3, concentration for 50% growth inhibition: 21500 nM
Compound 3: middle estimate off by 1.4-fold (0.14 log units), on the high side, within the range that was stated.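

In this assay, compound 3 is the only one of the three compounds shown to give a number rather than a limit, 21500 nM, so a change of the aryl group on this nitrogen can give a readable result. Putting 3-chloro-5-(trifluoromethyl)phenyl in place of 4-methoxy-3-(trifluoromethyl)phenyl gives an at least 1.3-fold lower number from compound 1 to compound 3 (0.14 log units; that floor lies within the scatter), and putting it in place of 4-(trifluoromethyl)phenyl gives an at least 1.3-fold lower number from compound 2 to compound 3 (0.14 log units; that floor lies within the scatter); each is only a floor and lies within the scatter, so neither step establishes a real gain at this position. The step from compound 1 to compound 2 still cannot be read, and the new number does not change that: the limit of > 30000 nM in this assay, at which 2 of the 3 values shown sit.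

The compounds shown leave open whether the chlorine itself or the pairing of chlorine with trifluoromethyl on the aryl ring goes with the readable number. They also leave open what a nitrile, an amine or a carboxylic acid in place of the chlorine would give in this assay.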